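Dropping a Methyl in the Core of Compound 3

The source may report more compounds than this note shows. Statements on the series, on what has been measured and on what is new or still open speak of the compounds shown alone.

Three compounds share a core and differ only in the aryl group on the carbon doubly bonded to nitrogen. Compound 1 `C[C@H](c1ccc(C(=O)NCCC(=O)O)cc1)N1C(=O)C(c2ccc(F)cc2)=N[C@]12CC[C@@H](C(C)(C)C)CC2` gives 85 nM in an assay on CHO cells for displacement of a labelled ligand from Glucagon receptor (Homo sapiens), read by scintillation counting, with a stated time of 60 min (a higher number here means a weaker inhibitor, a lower number a stronger inhibitor), compound 2 `C[C@H](c1ccc(C(=O)NCCC(=O)O)cc1)N1C(=O)C(c2cccc(C3CC3)c2)=N[C@]12CC[C@@H](C(C)(C)C)CC2` gives 56 nM, and compound 3 `C[C@H](c1ccc(C(=O)NCCC(=O)O)cc1)N1C(=O)C(c2cccc(Cl)c2)=N[C@]12CC[C@@H](C(C)(C)C)CC2` gives 130 nM, the highest of the three numbers, though a 1.5-fold higher number from compound 1 to compound 3 (0.18 log units; within the scatter) and a 2.3-fold higher number from compound 2 to compound 3 (0.37 log units; beyond the scatter). Compound 4 `CC(C)(C)[C@H]1CC[C@]2(CC1)N=C(c1cccc(Cl)c1)C(=O)N2Cc1ccc(C(=O)NCCC(=O)O)cc1` instead carries hydrogen in place of methyl on a saturated chain carbon bound to an amide-type nitrogen in a ring and an aromatic carbon. Among the measured compounds shown here, none of the measured steps touches this position; a 1.5-fold lower number from compound 1 to compound 2 (0.18 log units; within the scatter), a 1.5-fold higher number from compound 1 to compound 3 (0.18 log units; within the scatter) and a 2.3-fold higher number from compound 2 to compound 3 (0.37 log units; beyond the scatter) all concern the aryl group, so they offer no direct guide. Going by these compounds, the methyl is part of the shared core in every measured compound, so its removal is untested here, and compound 4 is expected to give a higher number, roughly a 3.5-fold higher number from compound 3 to compound 4 (0.54 log units; beyond the scatter). Compound 4 is estimated at 450 nM, between 130 nM and 1600 nM.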

Compound 4, half-maximal inhibitory concentration: 770 nM
For compound 4 the middle estimate is 1.7-fold (0.23 log units) below the measured one, and the stated range covers the measured number.
By their numbers in this assay, from the lowest: compounds 2, 1 and 3 (each within the scatter of the next, the first and the last beyond it); then compound 4.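

In this assay hydrogen in place of methyl on this saturated chain carbon gives a 5.9-fold higher number from compound 3 to compound 4 (0.77 log units; beyond the scatter) and that step is larger than any among the aryl changes of compound 1, compound 2 and compound 3. Among the compounds shown here, it shows that this position, constant in all the earlier compounds, bears on the number, with the methyl going with the lower number in this one pair. Nothing available explains the size of this step.

Open, going by these compounds, is whether a longer chain such as ethyl on this carbon would lower or raise the number. Also open, on these data alone, is whether the same change would give a similar step with the aryl groups of compound 1 and compound 2.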